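The compounds below may be only part of what the source reports. "The series", "measured", "known", "first", "only" and "open" are said of these compounds alone.

Measured compounds:
- compound 1, `CC(=O)c1ccc(NC(=O)CN(C(=O)c2ccccc2)S(=O)(=O)c2ccc(C)cc2)cc1`: 18.5% in a functional assay for inhibition, read by spectrophotometry, with a stated time of 20 min, tested at 4 mg/mL; a higher number here means a stronger effect of the compound at the concentration tested, a lower number a weaker effect
- compound 2, `CC(=O)c1ccc(NC(=O)CN(C(=O)c2ccccc2)S(=O)(=O)c2ccc([N+](=O)[O-])cc2)cc1`: 20.7% in this assay

Compound 2 stands within the usual scatter of compound 1, the step being a number 2.2 percentage points higher from compound 1 to compound 2 (within the scatter). Compound 3, `CCC(C)C(C(=O)Nc1ccc(C(C)=O)cc1)N(C(=O)c1ccccc1)S(=O)(=O)c1ccc([N+](=O)[O-])cc1`, has not yet been measured in this assay. Its change from compound 2 is sec-butyl in place of hydrogen on a saturated chain carbon bound to an amide-type nitrogen and a carbonyl carbon. Among the compounds with values here, the only measured step concerns a group on an aromatic carbon and does not bear on this change; no measured step touches the saturated chain carbon. Nothing therefore points to a step beyond the scatter in either direction, and compound 3 is expected to give about 22%, between 8% and 40%. The step this estimate means is a number 1.3 percentage points higher from compound 2 to compound 3 (within the scatter), expected to stay within the scatter.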

Compound 3, a percentage reported as inhibition, at one concentration (the size of the read-out at that concentration, not a potency): 48.4%
Compound 3: middle estimate off by 26.4 percentage points, on the low side; the measured number lies above the stated range.
By their numbers in this assay, from the lowest: compounds 1 and 2 (each within the scatter of the next); then compound 3.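

Unlike the earlier swap of nitro for methyl on an aromatic carbon, a change at the saturated chain carbon bound to an amide-type nitrogen and a carbonyl carbon moves the read-out in this assay with sec-butyl in place of hydrogen giving a number 27.7 percentage points higher from compound 2 to compound 3 (beyond the scatter) in this series. This carbon therefore need not carry hydrogen for inhibition to be seen. No measurement available here explains the step. Still open, from the compounds shown here alone, is how the read-out would respond to a methyl, a longer straight chain or an amine on this carbon, which would show whether sec-butyl itself matters or any added group gives a similar step.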